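The source may hold more compounds than are shown below. What is called first, only, known or untested is meant among the compounds shown, and "the series" means these compounds.

Working notes on the series in an ADME assay on HeLa cells (Homo sapiens) for cytotoxicity, read by MTT assay; on this read-out lower numbers stand for stronger inhibition and higher numbers for weaker inhibition. Going by the values given here, compound 1 `COc1ccc(C[C@H]2COC(=O)[C@@H]2Cc2ccc(OCc3cn(Cc4ccccc4F)nn3)c(OC)c2)cc1OC` gives only a limit of the assay, >= 600000 nM, the single value here that sits at the limit recorded as the limit of >= 600000 nM in this assay, at which 1 of the 3 values shown sits. Compound 3 `COc1ccc(C[C@H]2COC(=O)[C@@H]2Cc2ccc(OCc3cn(Cc4ccc(F)cc4)nn3)c(OC)c2)cc1OC` gives 198000 nM. Compound 2 `COc1ccc(C[C@H]2COC(=O)[C@@H]2Cc2ccc(OCC(=O)N3CCCCC3)c(OC)c2)cc1OC` gives 293000 nM; set against compound 3 the two numbers lie within the scatter of each other, so compound 2 is not told apart from compound 3 on this read-out. Among the compounds with values here, the only measured step within the set is an at least 3.0-fold lower number from compound 1 to compound 3 (0.48 log units; beyond the scatter), which concerns the fluorophenyl group on a saturated chain carbon bound to an aromatic nitrogen and leaves the amide side of the molecule untouched.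

Compound 4 `COc1ccc(C[C@H]2COC(=O)[C@@H]2Cc2ccc(OCC(=O)N3CCOCC3)c(OC)c2)cc1OC` differs from compound 2 in one place: morpholin-4-yl in place of piperidin-1-yl on a carbonyl carbon. Within the data shown here, no measured step bears on a change at the carbonyl carbon, and the one step known concerns a different part of compound 1 and compound 3, so it gives no guide in size or direction. The expectation is therefore no step beyond the scatter, a 1.0-fold higher number from compound 2 to compound 4 (0.01 log units; within the scatter). For compound 4 the estimate in this assay is 300000 nM, with a range from 150000 nM to 600000 nM.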

Compound 4, half-maximal inhibitory concentration: >= 600000 nM
Compound 4 ended at the assay's limit; the forecaster's own chance of this, stated with the estimate: 25%; middle value at least 2.0-fold (0.30 log units) away from the limit.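

In this assay, going by these compounds alone, the earlier compounds held no step at the carbonyl carbon, and this position now proves responsive: morpholin-4-yl in place of piperidin-1-yl gives an at least 2.0-fold higher number from compound 2 to compound 4 (0.31 log units; beyond the scatter). The two groups are each one six-membered non-aromatic ring with the same count of heavy atoms, and they differ in an oxygen standing where piperidin-1-yl has a carbon, which adds one hydrogen-bond acceptor, so a single atom exchange within the ring is enough here to move the number beyond the scatter. Compound 4 gives >= 600000 nM, which is a limit of the assay and not a number, and it is not alone there: the limit of >= 600000 nM in this assay, at which 2 of the 4 values shown sit.

From the compounds shown here alone, the full size of the step therefore stays open, as does whether the same exchange would act alike in a molecule other than compound 2. Also open, going by these compounds, is whether a pyrrolidine ring, a piperazine ring or an open-chain diethylamine on the same carbonyl carbon would read like compound 2 or like compound 4.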